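Swapping Anilino for Bromo on a Shared Core

The source may report more compounds than this note shows. Statements on the series, on what has been measured and on what is new or still open speak of the compounds shown alone.

Compound 3 `Cn1cc(-c2n[nH]c3ccc(Nc4ccccc4)cc23)cn1` gives 580 nM in an assay on isolated protein for inhibition of tyrosine-protein kinase receptor UFO (Homo sapiens), with a stated time of 1.5 h (a higher number here means a weaker inhibitor, a lower number a stronger inhibitor), the lowest of the two numbers recorded. Compound 2 `Cn1cc(-c2n[nH]c3ccc(N)cc23)cn1` gives 8910 nM in this assay. Compound 1 `Nc1ccc2c(Br)n[nH]c2c1` shows only a limit of the assay in this assay, > 770000 nM, and not a number (the limit of > 770000 nM in this assay, at which 1 of the 3 values shown sits). Among the measured compounds shown here, the one measured step, phenyl in place of hydrogen on a nitrogen on an aromatic ring, is sizeable. Compound 4 `Cn1cc(-c2n[nH]c3ccc(Br)cc23)cn1` differs from compound 3 by bromo in place of anilino on an aromatic carbon, so the phenyl and the nitrogen both leave. Because that phenyl carried the whole of a 15-fold lower number from compound 2 to compound 3 (1.19 log units; beyond the scatter), a large upward step is expected for compound 4, back toward the number of compound 2. Compound 4 is therefore estimated at 10000 nM in this assay, within 2500 nM to 40000 nM, an expected step of a 17-fold higher number from compound 3 to compound 4 (1.24 log units; beyond the scatter).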

Compound 4, half-maximal inhibitory concentration: 1540 nM
Compound 4: middle estimate off by 6.5-fold (0.81 log units), on the high side, and the stated range ends above it.
By their numbers in this assay, from the lowest: compound 3; then compound 4; then compound 2. At a limit, above all of these: compound 1.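

Bromo in place of amino gives a 5.8-fold lower number from compound 2 to compound 4 (0.76 log units; beyond the scatter), so on the shared core a phenyl-bearing group is not needed for a gain at this aromatic carbon. Bromo in place of anilino gives only a 2.7-fold higher number from compound 3 to compound 4 (0.42 log units; beyond the scatter), so the single bromine atom stays fairly close to the much larger anilino group, though the step is beyond the scatter. The evidence at hand gives no reason for this order. From the compounds shown here alone, it remains open whether chloro or methoxy at this carbon would match bromo. Equally open, going by these compounds, is whether a substituted anilino, such as one carrying a carboxylic acid or a longer amine chain, would go lower than compound 3.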